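Aryl swap on the shared core, cytotoxicity notes

A few compounds are considered here, and "the series" means these few. Any claim that something is new, unique, unknown or untested is made for them only; others in the source may bear on it.

Compound 1 `O=C1CSC(c2ccc(Cl)cc2)N1CCN1CCCCC1`, compound 2 `O=C1CSC(c2ccc([N+](=O)[O-])cc2)N1CCN1CCCCC1` and compound 3 `O=C1CSC(c2cccc(Cl)c2)N1CCN1CCCCC1` share a core and differ only in the aryl group on a saturated ring carbon. In an ADME assay on Vero cells (Chlorocebus sabaeus) for cytotoxicity, read by neutral red uptake, tested at 12.3 ug/mL (a lower number here means a stronger effect, a higher number a weaker effect of the compound at the concentration tested), compound 1 gives 90%, compound 2 gives 100% and compound 3 gives 100%. Compound 3 is level with compound 2, the pair together highest of the three, with compound 1 the furthest; yet the steps of a number 10 percentage points higher from compound 1 to compound 2 (within the scatter) and a number 10 percentage points higher from compound 1 to compound 3 (within the scatter) both lie within the scatter, so all three read as one flat level. Compound 4 `Cc1ccc(C2SCC(=O)N2CCN2CCCCC2)cc1` differs from compound 3 by 4-methylphenyl in place of 3-chlorophenyl on a saturated ring carbon. Among the measured compounds shown here, only the step from compound 1 to compound 3 concerns an aryl swap on that carbon, and it changed nothing beyond the scatter; no measured step involves a methyl group. A step of a number 3 percentage points lower from compound 3 to compound 4 (within the scatter) is expected, none beyond the scatter. For compound 4 in this assay a value of 97% is estimated, between 85% and 100%.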

Compound 4, a percentage reported as activity, at one concentration (the size of the read-out at that concentration, not a potency): 100%
The estimate for compound 4 lay 3 percentage points below the measured number; measured number inside the range.
By their numbers in this assay, from the lowest: compounds 1, 2, 3 and 4 (each within the scatter of the next).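

In this assay, a 4-methylphenyl group on the saturated ring carbon, with a substituent of carbon only, stays on the same flat level: no change at the digits printed from compound 3 to compound 4 (within the scatter), no change at the digits printed from compound 2 to compound 4 (within the scatter) and a number 10 percentage points higher from compound 1 to compound 4 (within the scatter). Methyl therefore joins chloro and nitro on the aryl group, with no step beyond the scatter among these compounds. No supporting data bear on this flat level. Open, going by these compounds, is whether an amine or a carboxylic acid on the aryl ring, or a longer chain in place of methyl, would leave this level.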